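This account rests on a few compounds, and the source may have more. Where it says the series, first, only, none or still open, it means among the compounds named here.

Measured so far:
- compound 1, `O=C(CSc1ncccn1)N/N=c1/scc(-c2ccc(F)cc2)n1-c1ccccc1`: 32.2%
- compound 2, `Cc1ccc(-c2cs/c(=N/NC(=O)CSc3ncccn3)n2-c2ccccc2)cc1`: 43.7%

Compound 2 stands as the higher of the two values in a functional assay on C6 cells (Rattus norvegicus) for cytotoxicity, read by MTT assay, with a stated time of 24 h, tested at 200 ug/mL; a lower number here means a stronger effect, a higher number a weaker effect of the compound at the concentration tested; compound 1 is the nearest, and the step of a number 11.5 percentage points higher from compound 1 to compound 2 (beyond the scatter) places it beyond the scatter. That step concerns only the substituent on the outer aromatic ring and says nothing about the sulfur-linked heteroaryl group.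

Compound 3, `Cc1ccc(-c2cs/c(=N/NC(=O)CSc3nnnn3C)n2-c2ccccc2)cc1`, differs from compound 2 as follows: 1-methyl-1H-tetrazol-5-yl in place of pyrimidin-2-yl on a sulfur. Among the measured compounds shown here, no measured step in this set touches this position, so there is no direct precedent for the size or direction of the change in this assay. For the measured compounds named here, the only available step, a number 11.5 percentage points higher from compound 1 to compound 2 (beyond the scatter), was modest and lies elsewhere in the molecule.

The working expectation is therefore that compound 3 stays near compound 2, with a step of a number 1.3 percentage points higher from compound 2 to compound 3 (within the scatter) not expected to pass beyond the scatter. Compound 3 is estimated at 45% in this assay, with a range from 30% to 62%.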

Compound 3, a percentage reported as activity, at one concentration (the size of the read-out at that concentration, not a potency): 39.7%
Estimate against measurement, compound 3: 5.3 percentage points above, and the stated range covers the measured number.
By their numbers in this assay, from the lowest: compounds 1, 3 and 2 (each within the scatter of the next, the first and the last beyond it).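

In this assay, the position on the sulfur now has its first reading, a number 4 percentage points lower from compound 2 to compound 3 (within the scatter). At this single concentration, pyrimidin-2-yl and 1-methyl-1H-tetrazol-5-yl are therefore not told apart, even though the exchange replaces a six-membered aromatic ring with 2 hetero atoms by a five-membered aromatic ring with 4 hetero atoms and changes the count from 2 to 4 hydrogen-bond acceptors. No supporting data bear on why these two groups read alike.

Going by these compounds, this reading comes from a single pair with methyl on the outer aromatic ring, so it remains open whether the same exchange would also stay within the scatter with fluoro there. On these data alone, it is also open whether this position responds to a group of a different kind, such as a simple phenyl ring, an amine or a carboxylic acid on the sulfur-linked chain, since the two groups compared here are both nitrogen-containing aromatic rings and the limits of the position remain undefined.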